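Methoxy beside the phenol: predicting compound 4

The source may hold more compounds than are shown below. What is called first, only, known or untested is meant among the compounds shown, and "the series" means these compounds.

Compounds measured in a functional assay on A549 cells (Homo sapiens) for cytotoxicity, read by MTT assay, with a stated time of 72 h; a lower number here means a stronger inhibitor, a higher number a weaker inhibitor:
compound 1 `CN(C)CCn1cnnc1-c1cc(Oc2ccc(NC(=O)N/N=C/c3ccc(Cl)cc3Cl)cc2F)ccn1` gives 810 nM
compound 2 `CN(C)CCn1cnnc1-c1cc(Oc2ccc(NC(=O)N/N=C/c3ccc(O)c(O)c3)cc2F)ccn1` gives > 100000 nM
compound 3 `CN(C)CCn1cnnc1-c1cc(Oc2ccc(NC(=O)N/N=C/c3ccc(O)cc3)cc2F)ccn1` gives 3560 nM

The value for compound 2 is a limit of this assay, not a number, as noted in the limit of > 100000 nM in this assay, at which 1 of the 3 values shown sits.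

Compound 3 stands as the highest of the two numbers; its nearest neighbour is compound 1, and a 4.4-fold higher number from compound 1 to compound 3 (0.64 log units; beyond the scatter) places the hydroxyphenyl analogue well above the dichlorophenyl analogue. The other step involving the hydroxy group is an at least 28-fold lower number from compound 2 to compound 3 (1.44 log units; beyond the scatter), with the dihydroxyphenyl compound reaching only the limit of the assay.

Compound 4 `COc1cc(/C=N/NC(=O)Nc2ccc(Oc3ccnc(-c4nncn4CCN(C)C)c3)c(F)c2)ccc1O` is not yet measured. It differs from compound 3 by methoxy in place of hydrogen on an aromatic carbon, so the change sits on the same ring at the position that carried the second hydroxy group in compound 2. The step that bears most directly is an at least 28-fold lower number from compound 2 to compound 3 (1.44 log units; beyond the scatter), which is large; but a methoxy is not a hydroxy, as the counted difference shows one acceptor and no donor, so a step of that size is not expected. A modest rise in the number, weaker than compound 3, seems the most likely outcome. Compound 4 is therefore expected to give about 7000 nM, within 2000 nM to 35000 nM, a step of a 2.0-fold higher number from compound 3 to compound 4 (0.29 log units; within the scatter).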

Compound 4, half-maximal inhibitory concentration: > 100000 nM
Compound 4: only a limit was reported (the forecaster's own chance of this, stated with the estimate: 10%); middle value at least 14-fold (1.15 log units) from the limit.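

In this assay compound 4 gives > 100000 nM, which is a limit and not a number. The methoxy, ortho to a hydroxy group on the 4-hydroxyphenyl ring, gives an at least 28-fold higher number from compound 3 to compound 4 (1.44 log units; beyond the scatter), so the loss seen earlier with a second hydroxy group on this aromatic carbon is not confined to that group: a methoxy here also takes the compound out of the readable range. Measured against the dichlorophenyl compound, the 4-hydroxy-3-methoxyphenyl ring gives an at least 120-fold higher number from compound 1 to compound 4 (2.09 log units; beyond the scatter), which shows that among the compounds shown, only the 2,4-dichlorophenyl and the unadorned 4-hydroxyphenyl rings keep a readable value.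

The step between compound 2 and compound 4 cannot be read, so the hydroxy and the methoxy cannot be ranked against each other at this position: the limit of > 100000 nM in this assay, at which 2 of the 4 values shown sit. As far as these compounds go, whether a fluorine, a methyl or an amine on this same aromatic carbon would stay close to compound 3 or also reach the limit remains open, as does the effect of a methoxy on the 4-hydroxyphenyl ring with its hydroxy group removed.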